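The source may report more compounds than this note shows. Statements on the series, on what has been measured and on what is new or still open speak of the compounds shown alone.

Compound 1 `CCOC(=O)/C=C1/C(=O)Nc2ccccc21` gives 57.3% in a functional assay on OVCAR-3 cells (Homo sapiens) for inhibition, read by CCK-8 assay, with a stated time of 72 h, tested at 20 uM; on this read-out higher numbers stand for more inhibition of growth at the one concentration tested and lower numbers for less inhibition of growth.
Compound 2 `CC(C)(C)OC(=O)/C=C1/C(=O)Nc2ccccc21` gives 59.6%.
Compound 3 `CC(C)(C)OC(=O)/C=C1/C(=O)Nc2ccc(OC(F)(F)F)cc21` gives 59%.

Among these three numbers compound 2 stands highest, but both of its neighbours lie within the scatter: a number 2.3 percentage points higher from compound 1 to compound 2 (within the scatter) and a number 0.6 percentage points lower from compound 2 to compound 3 (within the scatter). Compound 4 `CC(C)(C)OC(=O)/C=C1/C(=O)Nc2ccc([N+](=O)[O-])cc21` differs from compound 2 by nitro in place of hydrogen on an aromatic carbon. Among the compounds with values here, of the measured steps, only the one from compound 2 to compound 3 bears on this change, since it too replaced a hydrogen on an aromatic carbon of the shared core, and it stayed within the scatter. Nothing measured suggests that a nitro group should behave differently on this read-out, so no step beyond the scatter is expected: a number 0.6 percentage points lower from compound 2 to compound 4 (within the scatter). Compound 4 is therefore estimated at 59%, with a range from 45% to 72%.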

Compound 4, percent growth inhibition at one concentration: 55.6%
For compound 4 the middle estimate is 3.4 percentage points above the measured one; the range from low to high includes it.
By their numbers in this assay, from the lowest: compounds 4, 1, 3 and 2 (each within the scatter of the next).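

In this assay the second substituent at this aromatic carbon reads as a number 4 percentage points lower from compound 2 to compound 4 (within the scatter) and, against the first substituent, as a number 3.4 percentage points lower from compound 3 to compound 4 (within the scatter). Neither nitro nor trifluoromethoxy therefore separates from hydrogen or from each other at this carbon on growth inhibition at the one concentration tested. Nothing given here bears on the reason for this result. The compounds shown leave open whether an amine or a carboxylic acid at this carbon would move the number beyond the scatter. They also leave open what a methyl group in place of the amide hydrogen would do.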